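Chromanone anilide series: removing the phenyl from the amide

The source may report more compounds than this note shows. Statements on the series, on what has been measured and on what is new or still open speak of the compounds shown alone.

Measured so far:
compound 1 `COc1cc2c(cc1O)C(=O)CC(C(=O)Nc1ccccc1)O2` — 119000 nM
compound 2 `COc1cc2c(cc1O)CCC(C(=O)Nc1ccc([N+](=O)[O-])cc1)O2` — 40100 nM

In a functional assay on the whole organism for inhibition, with Rattus norvegicus as the target (on this read-out lower numbers stand for stronger inhibition and higher numbers for weaker inhibition), compound 1 gives 119000 nM, the higher of the two numbers on hand. Compound 2 gives 40100 nM in this assay, a lower number, and the gap between the two is beyond the usual scatter; the two compounds differ in several places at once, so nothing finer is drawn from that pair.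

Compound 3 `COc1cc2c(cc1O)C(=O)CC(C(N)=O)O2` is not yet measured. It differs from compound 1 by hydrogen in place of phenyl on an amide-type nitrogen. Going by the values given here, no single-point step between measured compounds is available to calibrate this change. The expectation is that the step in this assay from compound 1 to compound 3, a 1.7-fold higher number from compound 1 to compound 3 (0.23 log units; within the scatter), goes towards a higher number, a modest move that may not clear the scatter. For compound 3 the estimated value in this assay is 200000 nM, with a range from 60000 nM to 600000 nM.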

Compound 3, half-maximal inhibitory concentration: 214000 nM
For compound 3 the middle estimate is 1.1-fold (0.03 log units) below the measured one, and the stated range covers the measured number.
By their numbers in this assay, from the lowest: compound 2; then compounds 1 and 3 (each within the scatter of the next).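

Under this assay the change from anilino to amino gives a 1.8-fold higher number from compound 1 to compound 3 (0.25 log units; within the scatter) and so provides the first single-place step in the series. At this position on the amide-type nitrogen, losing the phenyl with its six carbon atoms does not separate compound 3 from compound 1 on this read-out, and both stand on the same core. No measured information bears on the reason for this outcome.

Open, on these data alone, is whether a methyl group, a benzyl group or a longer alkyl chain on that nitrogen would shift the number beyond the scatter. Compound 2 differs from compound 1 in several places, so the contributions of its nitro group and of the carbonyl present in compound 1 remain unseparated.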